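A fluoro step repeated on a second core

The source may hold more compounds than are shown below. What is called first, only, known or untested is meant among the compounds shown, and "the series" means these compounds.

Compound 1 `C[C@]1(CO)OC[C@@H](n2ccc(N)nc2=O)O1` and compound 3 `C[C@]1(CO)OCC(n2ccc(N)nc2=O)O1` are built from the same atoms and bonds, and they part only in one drawn stereocentre: the two compounds have the same atoms and bonds; at least one stereo element is drawn with a configuration in one of them and without one in the other: 1 of 2 stereo elements differ; a stereocentre at a saturated ring carbon is drawn S in compound 1 and without a configuration in compound 3. In a functional assay on B16-F10 cells (Mus musculus) for inhibition (a higher number here means a weaker inhibitor, a lower number a stronger inhibitor), compound 1 gives 100000 nM. In this assay compound 3 gives 100000 nM. Between the two there is no change at the digits printed from compound 1 to compound 3 (within the scatter); what separates the two drawings is the fact that one of compounds 1 and 3 is drawn with a defined configuration and the other without, at the place where they differ.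

Compound 2 `C[C@]1(CO)OC[C@@H](n2cc(F)c(N)nc2=O)O1` is compound 1 with one change: fluoro in place of hydrogen on an aromatic carbon. For compound 2 this assay reports only a limit of the assay, > 100000 nM. The step is therefore a number no lower from compound 1 to compound 2 (the limit leaves the size open), and the reason its size stays open is the limit of > 100000 nM in this assay, at which 1 of the 3 values shown sits.

Compound 4 `C[C@]1(CO)OCC(n2cc(F)c(N)nc2=O)O1` stands to compound 3 exactly as compound 2 stands to compound 1: fluoro in place of hydrogen on an aromatic carbon. The place of the change is word for word the same on both cores, so this is the same kind of change made a second time. Compound 4 has not yet been measured in this assay.

The step to compound 4 is expected to be no change at the digits printed from compound 3 to compound 4 (within the scatter). That expectation rests on the measured step of a number no lower from compound 1 to compound 2 (the limit leaves the size open), whose upper side is open through (the limit of > 100000 nM in this assay, at which 1 of the 3 values shown sits), and on compound 3 sitting level with compound 1. Compound 4 is estimated at 100000 nM, between 50000 nM and 200000 nM, with a real chance that this assay again returns only a limit rather than a number.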

Compound 4, half-maximal inhibitory concentration: > 100000 nM
Compound 4: no number, only a limit (the forecaster's own chance of this, stated with the estimate: 60%); the middle value sits exactly at the limit.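

In this assay compound 4 gives > 100000 nM, which is a limit of the assay and not a number. Fluoro in place of hydrogen on the aromatic carbon, carried to the second core, gives a number no lower from compound 3 to compound 4 (the limit leaves the size open), and the two steps stand together as follows: the same change on two cores in this assay, a number no lower (the limit leaves the size open) from compound 1 to compound 2 and a number no lower (the limit leaves the size open) from compound 3 to compound 4; the limit leaves it open whether they differ. This shows that on neither core did the change give a lower number, but it does not show that the change has the same size on both, and neither these sizes nor the step between compound 2 and compound 4 can be read, for this reason: the limit of > 100000 nM in this assay, at which 2 of the 4 values shown sit.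

The compounds shown leave open how a group other than fluoro at the same place, such as chloro, methyl or an amine, would read in this assay. They also leave open whether a longer chain on the saturated ring would bring a value clear of the limit, so that a change of this kind could be sized on either core.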